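Trifluoromethyl for aminocarbamoyl: expected cytotoxicity of compound 3

The source may report more compounds than this note shows. Statements on the series, on what has been measured and on what is new or still open speak of the compounds shown alone.

In an ADME assay on TZM cells (Homo sapiens) for cytotoxicity, read by XTT assay, with a stated time of 4 days (on this read-out higher numbers stand for lower toxicity in this test and lower numbers for higher toxicity in this test), compound 1 (`CC(=O)CCc1cc(C)c(Oc2cc(Nc3ccc(C#N)cc3)c(N)cc2C(F)(F)F)c(C)c1`) gives 11100 nM as a measured number. Compound 2 (`Cc1cc(CCC#N)cc(C)c1Oc1cc(Nc2ccc(C#N)cc2)c(N)cc1C(=O)NN`) stands only at a limit of the assay (> 22700 nM) and has no exact number.

Compound 3 (`Cc1cc(CCC#N)cc(C)c1Oc1cc(Nc2ccc(C#N)cc2)c(N)cc1C(F)(F)F`) follows from compound 2 with trifluoromethyl in place of aminocarbamoyl on an aromatic carbon. Within the data shown here, no measured pair in this assay isolates this exchange. The expectation therefore leans on compound 1, which also carries trifluoromethyl and gives 11100 nM in the same read-out. The expected step runs toward lower numbers, meaning higher toxicity, with an estimated size of an at least 2.2-fold lower number from compound 2 to compound 3 (0.35 log units; beyond the scatter) on this reckoning. In this assay compound 3 is estimated at 10000 nM with an expected range (4000 nM to 22000 nM).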

Compound 3, half-maximal cytotoxic concentration: > 7100 nM
Compound 3 was reported as a limit; the forecaster's own chance of this, stated with the estimate: 15%; the middle value is on the limit's open side.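

Among these compounds, no step to compound 3 can be read from compound 1 or compound 2 in this assay: compound 2 and compound 3 each stand only as limits. Still open, on these data alone, is the size and direction of the change for trifluoromethyl in place of aminocarbamoyl and for cyano in place of acetyl.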